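Replacing 2,4-difluorophenyl with isopropyl: working notes

A few compounds are considered here, and "the series" means these few. Any claim that something is new, unique, unknown or untested is made for them only; others in the source may bear on it.

Of the compounds shown here, two have numbers so far in a physicochemical assay for lipophilicity; on this read-out lower numbers stand for lower lipophilicity and higher numbers for higher lipophilicity. Compound 2 (`CCCCCCCN(CCCCCSc1[nH]cnc2ncnc1-2)C(=O)Nc1ccc(F)cc1F`) gives 5.32 and compound 1 (`CCCCCCCN(CCCCCSc1nc(N)c2c[nH]nc2n1)C(=O)NC(C)C`) gives 5.14, and these two numbers lie within the usual scatter of each other. Compound 2 therefore stands level with compound 1 on the data available, even though the two differ in more than one place.

Compound 3 (`CCCCCCCN(CCCCCSc1[nH]cnc2ncnc1-2)C(=O)NC(C)C`) keeps the core of compound 2 and has isopropyl in place of 2,4-difluorophenyl on an amide-type nitrogen. Among the measured compounds shown here, no measured pair isolates this change, so the expectation rests on the structural change itself and on one further observation. Compound 1 also carries isopropyl on an amide-type nitrogen and still gives 5.14, which argues against expecting a very large drop in this assay.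

A moderate downward move beyond the scatter is expected, with an estimated a number 0.62 log units lower from compound 2 to compound 3 (beyond the scatter). For compound 3 the expected value is 4.7, with an estimated range of 4.3 to 5.1.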

Compound 3, partition coefficient: 4.72
Estimate against measurement, compound 3: 0.02 log units below; measured number inside the range.
By their numbers in this assay, from the lowest: compound 3; then compounds 1 and 2 (each within the scatter of the next).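

In this assay, among the compounds shown here, with the core of compound 2 held fixed, isopropyl in place of 2,4-difluorophenyl on an amide-type nitrogen gives a number 0.60 log units lower from compound 2 to compound 3 (beyond the scatter), the first reading of this position taken alone. With isopropyl held fixed, the change of the group on the sulfur gives a number 0.42 log units lower from compound 1 to compound 3 (beyond the scatter), so this second place also moves the read-out, and the level standing of compounds 1 and 2 belongs to a pair that differs in both places. No measurement at hand explains the move at either place.

The compounds shown leave open how phenyl without fluorine or cyclohexyl on the amide-type nitrogen would read in this assay, so the step cannot yet be divided between the change of ring and the fluorine atoms. Also open, as far as these compounds go, is whether the step at the amide-type nitrogen keeps its size on the core of compound 1.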